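A few compounds are considered here, and "the series" means these few. Any claim that something is new, unique, unknown or untested is made for them only; others in the source may bear on it.

Measured so far in the series:
compound 1 `Cc1nsc2ncn([C@H]3C[C@H](O)[C@@H](CO)O3)c12`: > 100000 nM
compound 2 `CSc1nc2snc(C)c2n1[C@H]1C[C@H](O)[C@@H](CO)O1`: 32000 nM
compound 3 `Cc1nsc2c1ncn2[C@@H]1O[C@H](CO)[C@@H](O)[C@@H]1O`: > 100000 nM

In a functional assay on HFF cells (Homo sapiens) for inhibition (a lower number here means a stronger inhibitor, a higher number a weaker inhibitor), compound 1 returns only a limit, > 100000 nM. Compound 2 gives 32000 nM in this assay. As far as these compounds go, the step of an at least 3.1-fold lower number from compound 1 to compound 2 (0.49 log units; beyond the scatter) belongs to the change (methylsulfanyl in place of hydrogen on an aromatic carbon); because compound 1 sits at the limit of > 100000 nM in this assay, at which 2 of the 3 values shown sit, the full size of that step stays open.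

Compound 3 also returns only a limit in this assay, > 100000 nM. The difference between the cores of compound 1 and compound 3 is not broken down here.

Compound 4 `CSc1nc2c(C)nsc2n1[C@@H]1O[C@H](CO)[C@@H](O)[C@@H]1O` is still to be measured. Among the measured compounds shown here, it carries the same kind of change as the one from compound 1 to compound 2, (methylsulfanyl in place of hydrogen on an aromatic carbon); the place differs only in that the ring atom next to it bears a group of 9 heavy atoms rather than 8. Compound 4 is expected to show a step of an at least 1.6-fold lower number from compound 3 to compound 4 (0.22 log units; that floor lies within the scatter), resting on the step of an at least 3.1-fold lower number from compound 1 to compound 2 (0.49 log units; beyond the scatter). Compound 4 is estimated at 60000 nM, with a range from 20000 nM to 200000 nM. Since compound 3 sits at the limit of > 100000 nM in this assay, at which 2 of the 3 values shown sit, a reading that is again only a limit remains possible for compound 4.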

Compound 4, half-maximal inhibitory concentration: > 100000 nM
Compound 4: no number, only a limit; the forecaster's own chance of this, stated with the estimate: 45%; at least 1.6-fold (0.22 log units) between middle value and limit.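

Compound 4 returns only a limit in this assay, as compound 3 does, so no step can be read between compound 3 and compound 4. Both sit at the same limit: the limit of > 100000 nM in this assay, at which 3 of the 4 values shown sit.

The compounds shown leave open whether methylsulfanyl in place of hydrogen on an aromatic carbon changes the number at all on the core of compound 3.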